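Compound 1 losing one fluoro: expected exposure

A few compounds are considered here, and "the series" means these few. Any claim that something is new, unique, unknown or untested is made for them only; others in the source may bear on it.

In an ADME assay on the whole organism (Mus musculus, strain Swiss Webster) for pharmacokinetics, read by LC-MS, at a dose of 50 mg/kg by the oral route (on this read-out lower numbers stand for lower exposure and higher numbers for higher exposure at the dose given), compound 1 (`O=C(Nc1ccc(F)c(-c2nc3ncc(-c4cc(F)ccc4F)cc3[nH]2)c1)N1CCCC1`) gives 5620 ng.h/mL, second highest of three numbers. Compound 2 (`O=C(Nc1ccc(F)c(-c2nc3ncc(-c4ccc(F)cc4F)cc3[nH]2)c1)N1CCCC1`) gives 15600 ng.h/mL. Compound 3 (`O=C(Nc1ccc(F)c(-c2nc3ncc(-c4ccc(O)cc4)cc3[nH]2)c1)N1CCCC1`) gives 137 ng.h/mL. Compound 4 (`O=C(Nc1ccc(F)c(-c2nc3ncc(-c4cccc(F)c4)cc3[nH]2)c1)N1CCCC1`) carries one change: hydrogen in place of fluoro on an aromatic carbon, hydrogen in place of fluoro, ortho to a large group, giving 3-fluorophenyl. Going by the values given here, no measured step removes a fluoro alone. The nearest is modest, a 2.8-fold higher number from compound 1 to compound 2 (0.44 log units; beyond the scatter), and keeps both fluoro groups. The large steps, a 41-fold lower number from compound 1 to compound 3 (1.61 log units; beyond the scatter) and a 110-fold lower number from compound 2 to compound 3 (2.06 log units; beyond the scatter), both end at 4-hydroxyphenyl, which has no fluoro, so they bear only loosely. A small fall is expected, a 1.4-fold lower number from compound 1 to compound 4 (0.15 log units; within the scatter), probably within the scatter. Compound 4 is estimated at 4000 ng.h/mL, with an expected range of 1300 ng.h/mL to 12000 ng.h/mL.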

Compound 4, area under the concentration-time curve: 15000 ng.h/mL
Compound 4: the middle estimate sits 3.8-fold (0.57 log units) below what was measured, and the stated range ends below it.
By their numbers in this assay, from the lowest: compound 3; then compound 1; then compounds 4 and 2 (each within the scatter of the next).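

In this assay the loss of the fluoro ortho to a large group raises the number instead of lowering it (a 2.7-fold higher number from compound 1 to compound 4 (0.43 log units; beyond the scatter)), so exposure at this position does not depend on that fluoro. The 3-fluorophenyl and the 2,4-difluorophenyl cannot be told apart (a 1.0-fold lower number from compound 2 to compound 4 (0.02 log units; within the scatter)), while the 4-hydroxyphenyl remains far off (a 110-fold higher number from compound 3 to compound 4 (2.04 log units; beyond the scatter)). As far as these compounds go, whether an unsubstituted phenyl, a methoxy group or an amine on this ring would hold the exposure stays open. No evidence at hand accounts for the rise on losing the fluoro.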